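The source may report more compounds than this note shows. Statements on the series, on what has been measured and on what is new or still open speak of the compounds shown alone.

Compound 1 `Cc1cc(-c2c(F)cc3c(=O)ccn(C4CC4)c3c2F)cc(C)n1`: 15000 nM
Compound 2 `COc1cccc(Cc2cn(C3CC3)c3c(F)c(-c4cc(C)nc(C)c4)c(F)cc3c2=O)c1`: 20000 nM
Compound 3 `Cc1cc(-c2c(F)cc3c(=O)c(Cc4ccccc4N)cn(C4CC4)c3c2F)cc(C)n1`: 2100 nM

Of the compounds shown here, three sharing one core have been measured in a functional assay on P388 cells (Mus musculus) for cytotoxicity; a lower number here means a stronger inhibitor, a higher number a weaker inhibitor. Compound 1 gives 15000 nM, the second highest of the three numbers. Its nearest neighbour is compound 2, with a 1.3-fold higher number from compound 1 to compound 2 (0.12 log units; within the scatter); its furthest is compound 3, with a 7.1-fold lower number from compound 1 to compound 3 (0.85 log units; beyond the scatter). Between the two benzyl-bearing compounds there is a 9.5-fold lower number from compound 2 to compound 3 (0.98 log units; beyond the scatter).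

Compound 4 `Cc1cc(-c2c(F)cc3c(=O)c(Cc4cc(O)ccc4O)cn(C4CC4)c3c2F)cc(C)n1` has not yet been measured. It differs from compound 1 in one place: 2,5-dihydroxybenzyl in place of hydrogen on an aromatic carbon. The two steps that bear on this are the ones that also place a benzyl group on that aromatic carbon: the 3-methoxybenzyl step, which stayed within the scatter, and the 2-aminobenzyl step, which gave a modest lowering. For the measured compounds named here, the entering group here carries two hydrogen-bond donors, which neither measured benzyl group had, so no direct analogue exists. A modest lowering in this assay, smaller than that of compound 3, is expected, that is a 2.5-fold lower number from compound 1 to compound 4 (0.40 log units; beyond the scatter). Compound 4 is therefore estimated at 6000 nM, within a range of 1500 nM to 20000 nM.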

Compound 4, half-maximal inhibitory concentration: 360 nM
Compound 4: the middle estimate sits 17-fold (1.22 log units) above what was measured; the measured number lies below the stated range.
By their numbers in this assay, from the lowest: compound 4; then compound 3; then compounds 1 and 2 (each within the scatter of the next).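

In this assay, the position that carries hydrogen in compound 1 can support a large step, a 42-fold lower number from compound 1 to compound 4 (1.62 log units; beyond the scatter), whereas the earlier benzyl groups had shown nothing larger than a modest one. For the compounds shown here, the substitution on the benzyl ring also matters more than the earlier compounds revealed: 2,5-dihydroxyphenyl in place of 2-aminophenyl gives a 5.8-fold lower number from compound 3 to compound 4 (0.77 log units; beyond the scatter), and 2,5-dihydroxyphenyl in place of 3-methoxyphenyl gives a 56-fold lower number from compound 2 to compound 4 (1.74 log units; beyond the scatter). Placing a benzyl group here is therefore not enough on its own, and among these four compounds the lowest number comes with the 2,5-dihydroxybenzyl group.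

On these data alone, it remains open whether a 2-hydroxybenzyl group, a 3-hydroxybenzyl group or a carboxylic acid on the benzyl ring would give a similar number. Nothing available accounts for the size of this step.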